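This account rests on a few compounds, and the source may have more. Where it says the series, first, only, none or still open, it means among the compounds named here.

Compound 1 `CC(C)c1noc(N2CCN(C(=O)[C@@H]3CCCN(S(=O)(=O)c4ccc(S(=O)(=O)C5CCC5)cc4)C3)CC2)n1`: > 10000 nM in a functional assay on MIA PaCa-2 cells (Homo sapiens) for inhibition, read by MTT assay, with a stated time of 3 days (on this read-out higher numbers stand for weaker inhibition and lower numbers for stronger inhibition), a limit rather than a number.
Compound 2 `CC(C)c1noc(N2CCN(C(=O)[C@@H]3CCCN(S(=O)(=O)c4ccc(S(=O)(=O)NC(C)(C)C)cc4)C3)CC2)n1`: > 10000 nM in this assay, again only a limit.
Compound 3 `CC(C)NS(=O)(=O)c1ccc(S(=O)(=O)N2CCC[C@@H](C(=O)N3CCN(c4nc(C(C)C)no4)CC3)C2)cc1`: > 10000 nM in this assay, also a limit.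

Compound 3 therefore stands nowhere in particular on the numbers shown: its value is a limit, and the two other values shown are limits as well, since (the limit of > 10000 nM in this assay, at which 3 of the 3 values shown sit). The three compounds differ only at the sulfonyl sulfur, and the steps among them cannot be sized: a step that the two limits leave unreadable from compound 1 to compound 2, a step that the two limits leave unreadable from compound 1 to compound 3 and a step that the two limits leave unreadable from compound 2 to compound 3.

Compound 4 `CCNS(=O)(=O)c1ccc(S(=O)(=O)N2CCC[C@@H](C(=O)N3CCN(c4nc(C(C)C)no4)CC3)C2)cc1` takes the shortening one notch further: hydrogen in place of methyl on a saturated chain carbon bound to a saturated chain carbon and a sulfonamide nitrogen. Within the data shown here, the one measured step of the same kind, the loss of a methyl on the carbon bound to the sulfonamide nitrogen, is the step from compound 2 to compound 3, and it is unreadable because both ends sit at the limit. Among the measured compounds shown here, no measured step bears readably on the change, so no direction can be taken from them; the only evidence is that every trimming of this group so far has left the value at the limit.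

Compound 4 is accordingly expected to remain at the limit as well, with an estimated 15000 nM (range 5000 nM to 50000 nM), meaning an expected step that the limit leaves unreadable from compound 3 to compound 4.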

Compound 4, half-maximal inhibitory concentration: > 10000 nM
Compound 4 gave a limit, no number; the forecaster's own chance of this, stated with the estimate: 85%; the middle value is on the limit's open side.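

In this assay compound 4 gives > 10000 nM, which is a limit. None of its steps from compound 1, compound 2 or compound 3 can be read, because all four compounds sit at the same limit: the limit of > 10000 nM in this assay, at which 4 of the 4 values shown sit.

The compounds shown leave open how strongly any of the four inhibits and whether the groups on the sulfonyl sulfur differ at all.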